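This account rests on a few compounds, and the source may have more. Where it says the series, first, only, none or still open, it means among the compounds named here.

In a functional assay on RPMI-8226 cells (Homo sapiens) for inhibition, read by WST assay, with a stated time of 4 days (a lower number here means a stronger inhibitor, a higher number a weaker inhibitor), compound 1 `CC(C)(C)c1ccc(CN2CCN(S(=O)(=O)Nc3ccc(SCCc4ccccc4)cc3C(=O)O)CC2)cc1` gives 21300 nM and compound 2 `CCC(=O)N1CCN(c2c3ccc(-c4cccc(F)c4)cc3nn2Cc2ccccc2)CC1` gives 11800 nM, two numbers that lie within the usual scatter of each other. Compound 3 `C=CC(=O)N1CCN(c2c3ccc(-c4cccc(F)c4)cc3nn2Cc2ccccc2)CC1` differs from compound 2 in one place: vinyl in place of ethyl on a carbonyl carbon. The group that enters carries a double bond outside aromatic rings. Going by the values given here, no measured pair shows this change, so the expectation is a judgement from the structures alone. A clear step towards stronger inhibition is expected, estimated as a 3.9-fold lower number from compound 2 to compound 3 (0.59 log units; beyond the scatter). Compound 3 is estimated at 3000 nM, with an expected range from 600 nM to 15000 nM.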

Compound 3, half-maximal inhibitory concentration: 8700 nM
Estimate against measurement, compound 3: 2.9-fold (0.46 log units) below; the range from low to high includes it.
By their numbers in this assay, from the lowest: compounds 3, 2 and 1 (each within the scatter of the next, the first and the last beyond it).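

Putting vinyl in place of ethyl on a carbonyl carbon gives a 1.4-fold lower number from compound 2 to compound 3 (0.13 log units; within the scatter) in this assay. The added double bond therefore does not measurably separate these two compounds in this cell assay, and this position tolerates the change without a clear gain or loss. Nothing available explains this result. Still open, going by these compounds, is how a longer chain, an amine or a carboxylic acid at this carbonyl carbon would read, and whether any group there can move the number beyond the scatter.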